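The source may report more compounds than this note shows. Statements on the series, on what has been measured and on what is new or still open speak of the compounds shown alone.

In an ADME assay on BJ cells (Homo sapiens), read by MTT assay, with a stated time of 72 h (a higher number here means a weaker inhibitor, a lower number a stronger inhibitor), compound 2 `O=c1[nH]cnc2c1c(-c1cc3ccccc3o1)cn2[C@@H]1O[C@H](CO)[C@@H](O)[C@H]1O` gives 62700 nM. For compound 1 `O=c1[nH]cnc2c1c(-c1ccsc1)cn2[C@@H]1O[C@H](CO)[C@@H](O)[C@H]1O` this assay reports only a limit, > 100000 nM. The change thiophen-3-yl in place of 1-benzofuran-2-yl on an aromatic carbon thus gave an at least 1.5-fold higher number from compound 2 to compound 1 (0.20 log units; that floor lies within the scatter). Compound 3 `Cc1nc(N)c2c(-c3cc4ccccc4o3)cn([C@@H]3O[C@H](CO)[C@@H](O)[C@H]3O)c2n1` carries a different core; the difference between the two cores is not broken down here. For compound 3 this assay again reports only a limit, > 100000 nM. Compound 4 `Cc1nc(N)c2c(-c3ccsc3)cn([C@@H]3O[C@H](CO)[C@@H](O)[C@H]3O)c2n1` differs from compound 3 by the same change, (thiophen-3-yl in place of 1-benzofuran-2-yl on an aromatic carbon). The earlier step ran toward a higher number, and the starting point for compound 4 already sits at a limit, as the limit of > 100000 nM in this assay, at which 2 of the 3 values shown sit, shows. Compound 4 is therefore expected to remain at a limit rather than a number, with the expected step that the limit leaves unreadable from compound 3 to compound 4 small. The estimate for compound 4 is 150000 nM, within 100000 nM to 400000 nM.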

Compound 4, half-maximal inhibitory concentration: > 100000 nM
Compound 4 was reported as a limit; the forecaster's own chance of this, stated with the estimate: 90%; the middle value lies beyond the limit too.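

Compound 4 gives only a limit in this assay, > 100000 nM, and compound 3 is also a limit, so no step from compound 3 to compound 4 can be read: the limit of > 100000 nM in this assay, at which 3 of the 4 values shown sit.

The compounds shown leave open whether thiophen-3-yl in place of 1-benzofuran-2-yl changes the number on the core of compound 3.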